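Removing the Hydroxypropyl Chain from the Ring Nitrogen

The source may report more compounds than this note shows. Statements on the series, on what has been measured and on what is new or still open speak of the compounds shown alone.

Compound 1 `Cn1c(Cc2nn(C)c(=O)c3ccccc23)nnc1SCCCCCCCC(=O)Nc1ccc(Cl)cc1Cl` gives 350 nM in an assay on NK92 cells for inhibition of interleukin-2 (Homo sapiens), read by AlphaScreen, with stated times of 30 min and 1 h; on this read-out lower numbers stand for stronger inhibition and higher numbers for weaker inhibition. Compound 2 `Cn1nc(Cc2nnc(SCCCCCCCC(=O)Nc3ccc(Cl)cc3Cl)n2CCCO)c2ccccc2c1=O` reaches only the assay limit of > 30000 nM in this assay. Compound 3 `Cn1c(Cc2nn(CCCO)c(=O)c3ccccc23)nnc1SCCCCCCCC(=O)Nc1ccc(Cl)cc1Cl` likewise gives only the limit > 30000 nM in this assay. Compound 3 thus stands at the weak end of the three values shown, at a limit shared with compound 2 (the limit of > 30000 nM in this assay, at which 2 of the 3 values shown sit). The two recorded steps, an at least 85-fold higher number from compound 1 to compound 2 (1.93 log units; beyond the scatter) and an at least 85-fold higher number from compound 1 to compound 3 (1.93 log units; beyond the scatter), are both large losses arriving with the added hydroxyalkyl chain. Compound 4 `Cn1c(Cc2n[nH]c(=O)c3ccccc23)nnc1SCCCCCCCC(=O)Nc1ccc(Cl)cc1Cl` differs from compound 3 by hydrogen in place of 3-hydroxypropyl on an aromatic nitrogen, taking that chain away entirely. Those steps point to the chain as the source of the loss, so its removal is expected to reverse it, an at least 50-fold lower number from compound 3 to compound 4 (1.69 log units; beyond the scatter). Compound 4 is estimated at 600 nM, within 150 nM to 6000 nM.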

Compound 4, half-maximal inhibitory concentration: > 30000 nM
Compound 4 gave a limit, no number; the forecaster's own chance of this, stated with the estimate: 10%; middle value at least 50-fold (1.69 log units) away from the limit.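

Compound 4 gives only a limit, as compound 3 does, so the step between them cannot be read. The readable comparison is with compound 1: hydrogen in place of methyl on this aromatic nitrogen gives an at least 85-fold higher number from compound 1 to compound 4 (1.93 log units; beyond the scatter). Of the three groups shown on this nitrogen, only the methyl of compound 1 gives a number, while 3-hydroxypropyl and hydrogen both stop at a limit: the limit of > 30000 nM in this assay, at which 3 of the 4 values shown sit.

As far as these compounds go, it remains open whether ethyl or a plain propyl chain on this nitrogen would keep a measurable value. The limits also leave open how weak compound 3 and compound 4 really are.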